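Sulfonic Acid for Carboxylic Acid on a Thromboxane Antagonist Core

The compounds below may be only part of what the source reports. "The series", "measured", "known", "first", "only" and "open" are said of these compounds alone.

Compound 1, `CC(C)c1ccc2c(CCCCS(=O)(=O)Nc3ccccc3)cc(C(=O)O)c-2cc1`: 8700 nM
Compound 2, `CC(C)c1ccc2c(CCCCCS(=O)(=O)Nc3ccccc3)cc(C(=O)O)c-2cc1`: 1500 nM
Compound 3, `CC(C)c1ccc2c(CCCCS(=O)(=O)Nc3ccccc3)cc(S(=O)(=O)O)c-2cc1`: 1500 nM

These three compounds were tested in a functional assay on thoracic aorta for antagonist activity at thromboxane A2 receptor (Rattus norvegicus); on this read-out lower numbers stand for stronger inhibition and higher numbers for weaker inhibition. The change from compound 1 to compound 3 is sulfo in place of carboxy on an aromatic carbon, and it made a 5.8-fold lower number from compound 1 to compound 3 (0.76 log units; beyond the scatter). Compound 2 and compound 3 are level in this assay. The difference between the core of compound 1 and the core of compound 2 is not broken down here.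

Compound 4, `CC(C)c1ccc2c(CCCCCS(=O)(=O)Nc3ccccc3)cc(S(=O)(=O)O)c-2cc1`, is not yet measured. It differs from compound 2 by sulfo in place of carboxy on an aromatic carbon, the same change at the same place as that seen earlier. For the measured compounds named here, for compound 4 an expected step of a 3.8-fold lower number from compound 2 to compound 4 (0.57 log units; beyond the scatter) is estimated, resting on the single earlier step of a 5.8-fold lower number from compound 1 to compound 3 (0.76 log units; beyond the scatter), with some caution since only one example exists. The estimate for compound 4 in this assay is 400 nM, expected to lie between 150 nM and 1500 nM.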

Compound 4, half-maximal inhibitory concentration: 1400 nM
For compound 4 the middle estimate is 3.5-fold (0.54 log units) below the measured one; low and high end bracket the measured number.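

On a second core, sulfo in place of carboxy on an aromatic carbon gave a 1.1-fold lower number from compound 2 to compound 4 (0.03 log units; within the scatter) in this assay. The change therefore did not carry over at the size first seen, and the two steps differ: the same change on two cores in this assay, a 5.8-fold lower number (0.76 log units; beyond the scatter) from compound 1 to compound 3 and a 1.1-fold lower number (0.03 log units; within the scatter) from compound 2 to compound 4, 5.4-fold (0.73 log units) apart, beyond the scatter of two such steps

This shows that the size of the step depended on the core in this pair of cases, but it does not show why, nor how the change would behave on any other core. The compounds shown leave open whether a longer chain than that of compound 2 would bring the step back. They also leave open whether a tetrazole in place of the carboxy or sulfo group would track either step.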